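The source may hold more compounds than are shown below. What is called first, only, known or untested is meant among the compounds shown, and "the series" means these compounds.

In an ADME assay on cells (Homo sapiens) for cytotoxicity, read by resazurin assay, with a stated time of 5 days (on this read-out lower numbers stand for higher toxicity in this test and higher numbers for lower toxicity in this test), compound 1 `COc1ccc(-c2nc(CCc3cccc(Cl)c3)nc3ccsc23)cn1` gives > 50000 nM, which is a limit of the assay and not a number. Among the measured compounds shown here, compound 2 `COc1ccc(-c2nc(CC(O)c3cccc(Cl)c3)nc3ccsc23)cn1` gives 31000 nM, the only actual number so far. Compound 3 `COc1ccc(-c2nc(CSc3cccc(Cl)c3)nc3ccsc23)cn1` departs from compound 2 as follows: (3-chlorophenyl)sulfanyl in place of (3-chlorophenyl)(hydroxy)methyl on a saturated chain carbon bound to an aromatic carbon. For the measured compounds named here, one measured step bears on this change, an at least 1.6-fold lower number from compound 1 to compound 2 (0.20 log units; that floor lies within the scatter), which came from hydroxy in place of hydrogen on a saturated chain carbon and rests on (the limit of > 50000 nM in this assay, at which 1 of the 2 values shown sits). Since that step stays within the scatter, the expectation for a 1.0-fold higher number from compound 2 to compound 3 (0.01 log units; within the scatter) in this assay is no change beyond the scatter, in either direction, and a limit reading is also possible. For compound 3, the estimated value is 32000 nM, with an expected range of 14000 nM to 60000 nM.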

Compound 3, half-maximal cytotoxic concentration: > 10000 nM
Compound 3 was reported as a limit; the forecaster's own chance of this, stated with the estimate: 40%; the middle value lies beyond the limit too.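

In this assay compound 3 gives > 10000 nM, which is a limit of the assay and not a number. Among the compounds shown here, no step from compound 1 or compound 2 to compound 3 can be read. The compounds shown leave open whether (3-chlorophenyl)sulfanyl in place of (3-chlorophenyl)(hydroxy)methyl shifts the half-maximal cytotoxic concentration at all.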